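Low Cytotoxicity Across Three Related Ether Analogues

The compounds below may be only part of what the source reports. "The series", "measured", "known", "first", "only" and "open" are said of these compounds alone.

Compound 1 `CCC1(Cc2ccccc2)OS(=O)(=O)C=C1OCc1ccccc1`: >= 50000 nM
Compound 2 `CCC1(Cc2ccccc2)OS(=O)(=O)C=C1OCCCCc1ccccc1`: >= 20000 nM

In an ADME assay on HEL cells (Homo sapiens) for cytotoxicity, with a stated time of 3 days (on this read-out lower numbers stand for higher toxicity in this test and higher numbers for lower toxicity in this test), compound 1 gives >= 50000 nM, which is a limit of the assay rather than a number. Compound 2 likewise gives only a limit, >= 20000 nM. The step that the two limits leave unreadable from compound 1 to compound 2 therefore cannot be sized. Compound 3 `CCC1(Cc2ccccc2)OS(=O)(=O)C=C1OC(c1ccccc1)c1ccccc1` differs from compound 1 by phenyl in place of hydrogen on a saturated chain carbon bound to an aromatic carbon and an oxygen on an unsaturated carbon. Among the compounds with values here, only that unreadable step bears on it, so no size or direction can be expected beyond the scatter, and compound 3 is likely to sit at a limit as well. Compound 3 is expected to give 50000 nM, between 20000 nM and 200000 nM. That estimate means an expected step of a number no higher from compound 1 to compound 3 (the limit leaves the size open).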

Compound 3, minimum cytotoxic concentration: >= 80000 nM
Compound 3 ended at the assay's limit; the forecaster's own chance of this, stated with the estimate: 80%; middle value at least 1.6-fold (0.20 log units) from the limit.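

Compound 3 gives >= 80000 nM, a limit of the assay and not a number. Within the data shown here, compound 1 also gives only a limit, so no step from it to compound 3 can be read. The compounds shown leave open whether phenyl in place of hydrogen changes the read-out at all.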